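Lengthening the alkyl group on an inactive arylalkyne

This account rests on a few compounds, and the source may have more. Where it says the series, first, only, none or still open, it means among the compounds named here.

This set of compounds shares one core: a six-membered aromatic ring with two nitrogens joined through a carbon-carbon triple bond to a methyl-substituted benzene ring. They were tested in an assay on HEK293 cells for positive allosteric modulation of metabotropic glutamate receptor 5 (Rattus norvegicus); a lower number here means that less compound is needed, a higher number that more compound is needed for the effect. Compound 1 `CNc1ncc(C#Cc2ccc(C)cc2)cn1` carries a methylamino group on the core, and in this assay compound 1 gives 704000 nM, a weak effect that needs a great deal of compound. Compound 2 `Cc1ccc(C#Cc2cnc(C)nc2)cc1` carries a methyl group instead, and in this assay compound 2 gives "not active" (no number reported), so no number was reported for it. Compound 3 `CCc1ncc(C#Cc2ccc(C)cc2)cn1` carries an ethyl group, and in this assay compound 3 gives "not active" (no number reported), again with no number reported. Compound 3 therefore stands with compound 2 among the entries without a measurable effect, while only compound 1 produced a number at all, and that one is very high.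

The next compound, compound 4 `Cc1ccc(C#Cc2cnc(C(C)(C)C)nc2)cc1`, keeps everything but swaps the ethyl group: tert-butyl in place of ethyl on an aromatic carbon. Among the measured compounds shown here, no step between measured compounds is available to show what a change of this kind does in this assay. Since compound 3 gives "not active" (no number reported), no improvement beyond the scatter is expected, and the most likely outcome is again no number. Compound 4 is estimated in this assay at 600000 nM, within 100000 nM to 3000000 nM.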

Compound 4, half-maximal effective concentration: "not active" (no number reported)
The entry for compound 4 holds no number, so the estimate cannot be set against anything.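

Among the compounds shown here, neither compound 3 nor compound 4 gives a number in this assay, so no step from ethyl to tert-butyl can be read. No measured evidence accounts for this result. The compounds shown leave open whether any alkyl group on the shared core can produce a measurable effect in this assay.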